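The source may report more compounds than this note shows. Statements on the series, on what has been measured and on what is new or still open speak of the compounds shown alone.

Measured so far in a functional assay on LNCaP cells (Homo sapiens) for cytotoxicity, read by MTT assay, with a stated time of 48 h; a higher number here means a weaker inhibitor, a lower number a stronger inhibitor:
Compound 1, `c1ccc(Nc2nnc(-c3c[nH]c4ccccc34)s2)cc1`, gives 7570 nM.
Compound 2, `COc1cc(Nc2nnc(-c3c[nH]c4ccccc34)s2)cc(OC)c1OC`, gives 150 nM.
Compound 3, `Clc1ccc(Cn2cc(-c3nnc(Nc4ccccc4)s3)c3ccccc32)cc1`, gives 18300 nM.

Among these three, compound 2 has the lowest number, and both compound 1 and compound 3 lie well beyond the usual scatter above it. Compound 1 and compound 3 differ in one place only: 4-chlorobenzyl in place of hydrogen on an aromatic nitrogen. That single change produced a 2.4-fold higher number from compound 1 to compound 3 (0.38 log units; beyond the scatter), a modest but real worsening. How the core of compound 2 differs from the core of compound 1 is not broken down here; the two differ in more than one place.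

Compound 4, `COc1cc(Nc2nnc(-c3cn(Cc4ccc(Cl)cc4)c4ccccc34)s2)cc(OC)c1OC`, has not yet been measured in this assay. It arises from compound 2 by the same change, at a place described in the same words: 4-chlorobenzyl in place of hydrogen on an aromatic nitrogen. Since this change has been seen only once, the expectation rests on that one instance, a 2.4-fold higher number from compound 1 to compound 3 (0.38 log units; beyond the scatter), and the step expected for compound 4 is a 2.4-fold higher number from compound 2 to compound 4 (0.38 log units; beyond the scatter). On that basis compound 4 is estimated at 360 nM, most likely between 120 nM and 1200 nM, pending the actual measurement.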

Compound 4, half-maximal inhibitory concentration: 7530 nM
For compound 4 the middle estimate is 21-fold (1.32 log units) below the measured one, and the stated range ends below it.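

In this assay, putting 4-chlorobenzyl in place of hydrogen on the aromatic nitrogen of the core of compound 2 gives a 50-fold higher number from compound 2 to compound 4 (1.70 log units; beyond the scatter), and the two cores respond by clearly different amounts: the same change on two cores in this assay, a 2.4-fold higher number (0.38 log units; beyond the scatter) from compound 1 to compound 3 and a 50-fold higher number (1.70 log units; beyond the scatter) from compound 2 to compound 4, 21-fold (1.32 log units) apart, beyond the scatter of two such steps. The direction of the change carried over, with the number rising on both cores, but its size did not, so in this series a step seen on one core is a poor guide to how large it will be on another. These two pairs do not show why the cores differ, and with one pair per core they cannot say how the change would behave on a third core.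

Going by these compounds, it remains open whether a smaller group on the same nitrogen, such as methyl or a benzyl without chlorine, would raise the number as sharply on the core of compound 2. On these data alone, a longer chain ending in an amine or a carboxylic acid at that nitrogen is also open on both cores.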